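A few compounds are considered here, and "the series" means these few. Any claim that something is new, unique, unknown or untested is made for them only; others in the source may bear on it.

Two pairs of compounds carry one and the same structural change. Compound 1 `CC(C)N/C(=N\c1nccn1C(C)C)Nc1ccc(Cl)c(Cl)c1` and compound 2 `CC(C)N/C(=N\c1nccn1Cc1ccccc1)Nc1ccc(Cl)c(Cl)c1` differ only in this: benzyl in place of isopropyl on an aromatic nitrogen. In an in vitro ADME assay on microsomes from liver (Mus musculus) for metabolic stability, read by LC-MS, tested at 1 uM (a higher number here means that the compound lasts longer, a lower number that the compound disappears faster), compound 1 gives 0.0983 h, while compound 2 gives 0.3 h, so the step is a 3.1-fold higher number from compound 1 to compound 2 (0.48 log units; beyond the scatter). Compound 3 `CC(C)C(=O)N/C(=N/c1nccn1C(C)C)Nc1ccc(Cl)c(Cl)c1` rests on another core; the difference between the two cores is not broken down here. In this assay compound 3 reports only a limit of the method, > 1 h, and not a number, a point at which one of the three values shown sits (the limit of > 1 h in this assay, at which 1 of the 3 values shown sits). Compound 4 `CC(C)C(=O)N/C(=N/c1nccn1Cc1ccccc1)Nc1ccc(Cl)c(Cl)c1` carries the same change on the core of compound 3: benzyl in place of isopropyl on an aromatic nitrogen, with the same place in both pairs. Because the measured step from compound 1 to compound 2 was a 3.1-fold higher number from compound 1 to compound 2 (0.48 log units; beyond the scatter), the step from compound 3 to compound 4 is expected to be a step that the limit leaves unreadable from compound 3 to compound 4, though it starts from a limit and so cannot be pinned down. Compound 4 is therefore estimated at 1.8 h in this assay, likely between 0.8 h and 4 h, and will most probably again be reported only as a limit.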

Compound 4, half-life: 0.183 h
Compound 4: middle estimate off by 9.8-fold (0.99 log units), on the high side; the whole stated range lies above it.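

In this assay, putting benzyl in place of isopropyl on the aromatic nitrogen gives an at least 5.4-fold lower number from compound 3 to compound 4 (0.73 log units; beyond the scatter). This change therefore cannot be carried from one core to the other as a fixed step, not even in its direction: the same change on two cores in this assay, a 3.1-fold higher number (0.48 log units; beyond the scatter) from compound 1 to compound 2 and an at least 5.4-fold lower number (0.73 log units; beyond the scatter) from compound 3 to compound 4, at least 16-fold (1.22 log units) apart, beyond the scatter of two such steps. On these data alone, compound 3 gives > 1 h, which is a limit and not a number, so the true size of this step stays unknown, and two pairs cannot show which feature of the cores decides the direction.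

The compounds shown leave open whether the opposite directions hold for other groups on the aromatic nitrogen, such as a methyl, a longer chain such as n-butyl, or a phenethyl. They also leave open how a group carrying an amine or a carboxylic acid at that place would behave on the core of compound 1 and on the core of compound 3.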